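Removing One Nitro Group: Tolerated Concentration on Vero Cells

A few compounds are considered here, and "the series" means these few. Any claim that something is new, unique, unknown or untested is made for them only; others in the source may bear on it.

Compound 1 `COc1ccc(-c2nc3cc(Cl)c(Cl)cc3[nH]2)cc1`: 30000 nM
Compound 2 `COc1ccc(-c2nc3cc(Cl)c(Cl)cc3[nH]2)c([N+](=O)[O-])c1`: 80000 nM
Compound 3 `O=[N+]([O-])c1ccc(-c2nc3ccccc3[nH]2)c([N+](=O)[O-])c1`: a limit, > 100000 nM

All three were tested in an ADME assay on Vero cells (Chlorocebus sabaeus) for cytotoxicity; a higher number here means that more compound is tolerated, a lower number that less compound is tolerated. Compound 3 sits at the limit of > 100000 nM in this assay, at which 1 of the 3 values shown sits; its value is a limit, not a number. Compound 4 `O=[N+]([O-])c1ccccc1-c1nc2ccccc2[nH]1` is not yet measured. It differs from compound 3 by hydrogen in place of nitro on an aromatic carbon. Compound 1 differs from compound 2 by hydrogen in place of nitro on an aromatic carbon. The two are the same kind of change, but the surroundings differ: in compound 2 the carbon is ortho to a large group and meta to a methoxy group, while in compound 3 it is meta to a nitro group and para to a group of 9 heavy atoms. The difference between the two cores is not broken down here. The measured step was a 2.7-fold lower number from compound 2 to compound 1 (0.43 log units; beyond the scatter), so less compound was tolerated once the nitro was gone. For compound 4 a step of comparable size is expected, an at least 1.6-fold lower number from compound 3 to compound 4 (0.22 log units; that floor lies within the scatter), which rests on a 2.7-fold lower number from compound 2 to compound 1 (0.43 log units; beyond the scatter). Compound 4 is estimated at 60000 nM, likely between 25000 nM and 140000 nM.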

Compound 4, half-maximal cytotoxic concentration: > 100000 nM
Compound 4: a limit, no number; the forecaster's own chance of this, stated with the estimate: 25%; middle value at least 1.6-fold (0.22 log units) away from the limit.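

In this assay, compound 4 gives > 100000 nM, which is a limit and not a number. Compound 3 gives > 100000 nM, also a limit, so no step can be read from compound 3 to compound 4 because both sit at the same limit: the limit of > 100000 nM in this assay, at which 2 of the 4 values shown sit.

The compounds shown leave open whether losing this nitro lowers the tolerated concentration here, as it did between compound 2 and compound 1.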